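Amide aryl variation on the shared flavonol core

A few compounds are considered here, and "the series" means these few. Any claim that something is new, unique, unknown or untested is made for them only; others in the source may bear on it.

For the measured compounds named here, compound 2 `Cc1cc(C(=O)Nc2cccc(-c3oc4cc(-c5ccc(F)cc5)ccc4c(=O)c3O)c2)ccc1F` is the benzamide bearing a 4-fluoro-3-methylphenyl on the carbonyl carbon; in a functional assay on HepG2 cells (Homo sapiens) for antiproliferative activity, read by CCK-8 assay, with a stated time of 72 h (on this read-out higher numbers stand for weaker inhibition and lower numbers for stronger inhibition), compound 2 gives 9540 nM, the lowest of the two numbers so far. Going by the values given here, its only neighbour is compound 1 `CCc1ccc(C(=O)Nc2cccc(-c3oc4cc(-c5ccc(F)cc5)ccc4c(=O)c3O)c2)cc1`, which in this assay gives 20600 nM; the step of a 2.2-fold lower number from compound 1 to compound 2 (0.33 log units; beyond the scatter) was modest but beyond the scatter. Compound 3 `O=C(Nc1cccc(-c2oc3cc(-c4ccc(F)cc4)ccc3c(=O)c2O)c1)c1cc(F)cc(F)c1` carries the change (3,5-difluorophenyl in place of 4-fluoro-3-methylphenyl on a carbonyl carbon), that is, on the carbonyl carbon next to the amide-type nitrogen a 3,5-difluorophenyl replaces the 4-fluoro-3-methylphenyl. Among the compounds with values here, only the single aryl exchange from compound 1 to compound 2 bears on this, and it was small, so for compound 3 a step of at most similar size in this assay is expected, with no clear direction. Compound 3 is thus estimated at 10000 nM in this assay, within 4000 nM to 25000 nM, meaning an expected step of a 1.0-fold higher number from compound 2 to compound 3 (0.02 log units; within the scatter).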

Compound 3, half-maximal inhibitory concentration: 4960 nM
Estimate against measurement, compound 3: 2.0-fold (0.30 log units) above; measured number inside the range.
By their numbers in this assay, from the lowest: compounds 3 and 2 (each within the scatter of the next); then compound 1.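

Exchanging the 4-fluoro-3-methylphenyl for 3,5-difluorophenyl on the carbonyl carbon gives a 1.9-fold lower number from compound 2 to compound 3 (0.28 log units; within the scatter) in this assay, so these two aryl groups are not separated at this position. Against the 4-ethylphenyl of compound 1, the 3,5-difluorophenyl gives a 4.2-fold lower number from compound 1 to compound 3 (0.62 log units; beyond the scatter) and thus the largest step so far in the series, though still a modest one, and both compound 2 and compound 3 stand apart from compound 1. No evidence on why these aryl groups differ accompanies these numbers.

The compounds shown leave open whether a dimethylamino group or a carboxylic acid on this aryl ring, or a cyclohexyl on the carbonyl carbon, would move the number further than these steps. They also leave open what a single substituent exchange does, since each pair here differs in more than one substituent on the aryl ring.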